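Removing the benzyl from compound 2: an expectation

A few compounds are considered here, and "the series" means these few. Any claim that something is new, unique, unknown or untested is made for them only; others in the source may bear on it.

Measured compounds:
compound 1 `Cc1c(CC(O)CO)n(COCC[Si](C)(C)C)c(=O)[nH]c1=O` — > 100000 nM
compound 2 `COCn1c(CC(O)COCc2ccccc2)c(C)c(=O)[nH]c1=O` — > 100000 nM

In a functional assay on HepG2 cells (Homo sapiens) for antiproliferative activity, read by MTT assay, with a stated time of 72 h (a lower number here means a stronger inhibitor, a higher number a weaker inhibitor), compound 2 gives > 100000 nM, which is a limit of the assay and not a number. In this assay compound 1 likewise gives > 100000 nM, again a limit. Compound 2 thus stands where every value shown sits, at the limit of > 100000 nM in this assay, at which 2 of the 2 values shown sit. Compound 3 `COCn1c(CC(O)CO)c(C)c(=O)[nH]c1=O` differs from compound 2 in one place: hydrogen in place of benzyl on an oxygen on a saturated carbon. Going by the values given here, no measured step shows what this change does in this assay; with both measured compounds at the limit, no step beyond the scatter is expected, and a step that the limit leaves unreadable from compound 2 to compound 3 is estimated. Compound 3 is therefore expected to give 150000 nM, between 50000 nM and 500000 nM, most likely again as a limit.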

Compound 3, half-maximal inhibitory concentration: > 100000 nM
Compound 3 was reported as a limit (the forecaster's own chance of this, stated with the estimate: 85%); the middle value does not contradict the limit.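

The steps from compound 2 to compound 3 and from compound 1 to compound 3 cannot be read in this assay, where all three compounds share one limit: the limit of > 100000 nM in this assay, at which 3 of the 3 values shown sit. Any order among compound 1, compound 2 and compound 3 stays open, as does what hydrogen in place of benzyl does to activity.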